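This account rests on a few compounds, and the source may have more. Where it says the series, first, only, none or still open, it means among the compounds named here.

Compound 1 `CC1(C)Cc2c(ccc(C(=O)/C=C/c3ccc(Cl)cc3Cl)c2OCc2ccccc2)O1`: > 100000 nM, a limit
Compound 2 `CC1(C)Cc2c(OCc3ccccc3)ccc(C(=O)/C=C/c3ccc(Br)cc3)c2O1`: > 100000 nM, a limit

In a functional assay on HT-29 cells (Homo sapiens) for antiproliferative activity, read by MTT assay, with a stated time of 48 h (a higher number here means a weaker inhibitor, a lower number a stronger inhibitor), neither measured compound gives a number, since both sit at the limit of > 100000 nM in this assay, at which 2 of the 2 values shown sit. For the measured compounds named here, compound 1 therefore stands only on a limit, and the one other value shown is a limit as well, so no order between the two can be read. Compound 3 `CC1(C)Cc2c(ccc(C(=O)/C=C/c3ccc(F)cc3)c2OCc2ccccc2)O1` differs from compound 1 by 4-fluorophenyl in place of 2,4-dichlorophenyl on a double-bonded chain carbon bound to a double-bonded chain carbon. Going by the values given here, no measured step between two compounds is available. The expected change is a number no higher from compound 1 to compound 3 (the limit leaves the size open), that is, none beyond the usual scatter. Compound 3 is estimated at 100000 nM, with a range from 30000 nM to 300000 nM, and most likely again only a limit.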

Compound 3, half-maximal inhibitory concentration: 23000 nM
Compound 3: middle estimate off by 4.3-fold (0.64 log units), on the high side; measured number outside the range, below it.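

In this assay, the group on a double-bonded chain carbon bound to a double-bonded chain carbon can change the result: 4-fluorophenyl in place of 2,4-dichlorophenyl gives an at least 4.3-fold lower number from compound 1 to compound 3 (0.63 log units; beyond the scatter). This position therefore affects the read-out, and the series now has a measured number to compare against. The full size of the step remains unknown because compound 1 stands only on a limit: the limit of > 100000 nM in this assay, at which 2 of the 3 values shown sit.

Still open, as far as these compounds go, is whether adding the fluorine or losing the chlorines drives the change. Also open, from the compounds shown here alone, is how an amine or a carboxylic acid on that phenyl ring would read.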